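A few compounds are considered here, and "the series" means these few. Any claim that something is new, unique, unknown or untested is made for them only; others in the source may bear on it.

Values in a toxicity assay on MT4 cells (Homo sapiens) for cytotoxicity, read by MTT assay; on this read-out lower numbers stand for higher toxicity in this test and higher numbers for lower toxicity in this test:
- compound 1 `Cc1cc(-c2cccc(Cl)c2)cc(C)c1Oc1cc(N)nc(Nc2ccc(C#N)cc2)n1` gives 22300 nM
- compound 2 `Cc1ccccc1-c1cc(C)c(Oc2cc(N)nc(Nc3ccc(C#N)cc3)n2)c(C)c1` gives 25600 nM
- compound 3 `COc1ccccc1-c1cc(C)c(Oc2cc(N)nc(Nc3ccc(C#N)cc3)n2)c(C)c1` has not yet been measured

In this assay, for the measured compounds named here, compound 2 stands at 25600 nM and sits within the scatter of compound 1, its only measured neighbour. Compound 3 differs from compound 2 in one place: methoxy in place of methyl on an aromatic carbon. This is methoxy in place of methyl on an aromatic carbon, ortho to a large group, so that 2-methylphenyl becomes 2-methoxyphenyl.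

Going by the values given here, only one measured step bears on this change. It is a 1.1-fold higher number from compound 1 to compound 2 (0.06 log units; within the scatter), and it exchanges 3-chlorophenyl for 2-methylphenyl on an aromatic carbon. Among the compounds with values here, that step alters the same group, although no measured compound yet carries methoxy, so the evidence is thin. No shift beyond the scatter is expected in either direction, and the estimated step is a 1.1-fold lower number from compound 2 to compound 3 (0.05 log units; within the scatter). For compound 3 the expected value is 23000 nM, with an estimated range from 11000 nM to 46000 nM.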

Compound 3, half-maximal cytotoxic concentration: 21800 nM
Compound 3: the middle estimate sits 1.1-fold (0.02 log units) above what was measured; low and high end bracket the measured number.
By their numbers in this assay, from the lowest: compounds 3, 1 and 2 (each within the scatter of the next).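

Placing an oxygen on this ring for the first time, at the aromatic carbon ortho to a large group, gives a 1.2-fold lower number from compound 2 to compound 3 (0.07 log units; within the scatter) in this assay. Methoxy, which adds a hydrogen-bond acceptor that methyl lacks, therefore leaves the cytotoxicity reading indistinguishable from that of the methyl compound, and the comparison with the chloro compound agrees, with a 1.0-fold lower number from compound 1 to compound 3 (0.01 log units; within the scatter), so 3-chlorophenyl, 2-methylphenyl and 2-methoxyphenyl all read alike within the scatter on the shared core. No supporting data are available to account for this sameness.

From the compounds shown here alone, what remains open is whether this tolerance extends to groups of a different kind at the same place, such as an amine or a carboxylic acid, or to a longer chain such as ethoxy. The three compounds also leave open whether 2-methoxyphenyl and 2-methylphenyl would still read alike on a different core, since all of them share one core and differ only in this aryl group.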